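Sulfamoyl Replaces Fluorine on a Very Weak Inhibitor

The source may report more compounds than this note shows. Statements on the series, on what has been measured and on what is new or still open speak of the compounds shown alone.

Compound 1 `O=C(O)c1cnc2cc(F)ccc2c1O` was tested in an assay on isolated protein with malate dehydrogenase, mitochondrial (Sus scrofa) as the target (a higher number here means a weaker inhibitor, a lower number a stronger inhibitor), where compound 1 gives 10500000 nM, the higher of the two numbers seen so far. Compound 2 `O=C(O)c1cnc2cc(OCc3cccc4ccccc34)ccc2c1O` in this assay gives 13200 nM, a far lower number, beyond the scatter. Compound 3 `NS(=O)(=O)c1ccc2c(O)c(C(=O)O)cnc2c1` is compound 1 with sulfamoyl in place of fluoro on an aromatic carbon. Among the compounds with values here, no pair of measured compounds shows this same change, so the expected size rests on judgment alone. A modest step toward a lower number, a 3.5-fold lower number from compound 1 to compound 3 (0.54 log units; beyond the scatter), is expected in this assay. Compound 3 is estimated at 3000000 nM, within 500000 nM to 20000000 nM.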

Compound 3, half-maximal inhibitory concentration: 955000 nM
Compound 3: middle estimate off by 3.1-fold (0.50 log units), on the high side, within the range that was stated.
By their numbers in this assay, from the lowest: compound 2; then compound 3; then compound 1.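

Sulfamoyl in place of fluoro gives an 11-fold lower number from compound 1 to compound 3 (1.04 log units; beyond the scatter) in this assay, so this aromatic carbon can carry a group with more heavy atoms and a hydrogen-bond donor while the number still falls. Even so, compound 3 at 955000 nM stays well above compound 2 at 13200 nM. No measurement at hand explains why this change lowers the number. Still open, as far as these compounds go, is how an amine or a carboxylic acid on this same aromatic carbon would compare with sulfamoyl, and whether either would bring the number closer to that of compound 2.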